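The compounds below may be only part of what the source reports. "The series", "measured", "known", "first", "only" and "open" are said of these compounds alone.

Measured so far in an ADME assay on Vero cells (Chlorocebus sabaeus) for cytotoxicity, with a stated time of 72 h; a higher number here means a weaker inhibitor, a lower number a stronger inhibitor:

Compound 1 `O=[N+]([O-])c1cn2c(n1)OC[C@@H](OCc1cccc(-c3ccc(F)cc3)c1)C2` gives > 128000 nM, which is a limit of the assay rather than a number.

Compound 2 `O=[N+]([O-])c1cn2c(n1)OC[C@@H](OCc1csc(-c3ccc(C(F)(F)F)cc3)n1)C2` gives > 128000 nM, again a limit of the assay.

Compound 2 therefore stands at the limit of > 128000 nM in this assay, at which 2 of the 2 values shown sit, so no ordering between the two is possible. Compound 3 `O=[N+]([O-])c1cn2c(n1)OC[C@@H](OCc1csc(-c3ccc(F)cc3)n1)C2` is not yet measured; it differs from compound 2 by fluoro in place of trifluoromethyl on an aromatic carbon. With only limits to go on, the step that the limit leaves unreadable from compound 2 to compound 3 is expected to stay within the scatter, in no particular direction. Compound 3 is estimated at 200000 nM in this assay, within 80000 nM to 600000 nM, most likely reported again only as a limit.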

Compound 3, half-maximal inhibitory concentration: > 128000 nM
Compound 3: a limit, no number; the forecaster's own chance of this, stated with the estimate: 85%; the middle value lies beyond the limit too.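

For the compounds shown here, compound 2 and compound 3 both sit at the limit of this assay, so no step between them can be read: the limit of > 128000 nM in this assay, at which 3 of the 3 values shown sit.

The compounds shown leave open where the true value of each lies, and so whether fluoro in place of trifluoromethyl makes any difference.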